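This account rests on a few compounds, and the source may have more. Where it says the series, first, only, none or still open, it means among the compounds named here.

Compound 1, `COc1c(OCCCN2CCN(C)CC2)cc(O)c2c(=O)cc(-c3ccccc3)oc12`, gives 9900 nM; compound 2, `COc1c(OCCCCN2CCCC2)cc(O)c2c(=O)cc(-c3ccccc3)oc12`, gives 1530 nM; and compound 3, `COc1c(OCc2nc3ccccc3[nH]2)cc(O)c2c(=O)cc(-c3ccccc3)oc12`, sits at the limit > 100000 nM.

In a functional assay on A549 cells (Homo sapiens) for cytotoxicity, read by MTT assay, with a stated time of 48 h (a lower number here means a stronger inhibitor, a higher number a weaker inhibitor), compound 3 stands apart from the other two: its result is a limit of the assay rather than a number, and the limit of > 100000 nM in this assay, at which 1 of the 3 values shown sits, marks it as the only one of the three to do so. Compound 4, `COc1c(OCCCCN2CCN(C)CC2)cc(O)c2c(=O)cc(-c3ccccc3)oc12`, has not yet been measured. It differs from compound 3 by 3-(4-methylpiperazin-1-yl)propyl in place of 1H-benzimidazol-2-yl on a saturated chain carbon bound to an oxygen on an aromatic ring.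

Going by the values given here, two measured steps bear on this change, both running toward compound 3. The step of an at least 10-fold higher number from compound 1 to compound 3 (1.00 log units; beyond the scatter) replaced a chain carrying the 4-methylpiperazin-1-yl group with the benzimidazole and raised the number. The step of an at least 65-fold higher number from compound 2 to compound 3 (1.81 log units; beyond the scatter) did the same from the pyrrolidine chain and raised it further. Compound 4 returns to a basic amine on a saturated chain bound to the aromatic oxygen, and carries the same 4-methylpiperazin-1-yl group as compound 1, so the reverse of those steps is expected.

Compound 4 is therefore expected to show a large drop in the number, an at least 20-fold lower number from compound 3 to compound 4 (1.30 log units; beyond the scatter), with an estimated value of 5000 nM, in the range 1500 nM to 20000 nM.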

Compound 4, half-maximal inhibitory concentration: 1500 nM
Compound 4: middle estimate off by 3.3-fold (0.52 log units), on the high side, and the stated range covers the measured number.
By their numbers in this assay, from the lowest: compounds 4 and 2 (each within the scatter of the next); then compound 1. At a limit, above all of these: compound 3.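

Putting 3-(4-methylpiperazin-1-yl)propyl in place of 1H-benzimidazol-2-yl on a saturated chain carbon bound to an oxygen on an aromatic ring gives, in this assay, an at least 66-fold lower number from compound 3 to compound 4 (1.82 log units; beyond the scatter), a size that rests on a limit of the assay rather than on a number: the limit of > 100000 nM in this assay, at which 1 of the 4 values shown sits.

With the 4-methylpiperazin-1-yl group kept, (4-methylpiperazin-1-yl)methyl in place of 4-methylpiperazin-1-yl gives a 6.6-fold lower number from compound 1 to compound 4 (0.82 log units; beyond the scatter), so the chain alone now accounts for a step beyond the scatter, which the earlier comparison of two compounds differing in both chain and amine could not separate. On the longer chain, 4-methylpiperazin-1-yl in place of pyrrolidin-1-yl gives a 1.0-fold lower number from compound 2 to compound 4 (0.01 log units; within the scatter), which lies within the scatter, so this pair does not tell the two amines apart.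

From the compounds shown here alone, whether a still longer chain would carry the same result remains open, as does the effect of another amine at its end, such as morpholine or dimethylamine. The compounds shown also leave open how 1H-benzimidazol-2-yl would behave at the end of a longer chain, where the comparison with compound 4 would rest on the end group alone.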